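The source may report more compounds than this note shows. Statements on the series, on what has been measured and on what is new or still open speak of the compounds shown alone.

Compound 1 `CN(C)CCn1c(=O)sc2cc(S(=O)(=O)c3ccccc3)ccc21` was examined in an assay on HEK293 cells for displacement of a labelled ligand from 5-hydroxytryptamine receptor 6 (Homo sapiens), read by radioligand binding, with a stated time of 60 min, tested at 100 nM (on this read-out higher numbers stand for more inhibition at the one concentration tested (going by the name of the read-out) and lower numbers for less inhibition), where compound 1 gives 16%. Two related compounds were measured alongside it. Compound 2 `O=c1sc2cc(S(=O)(=O)c3ccccc3)ccc2n1CCN1CCCCC1` gives 11% in this assay, and compound 3 `O=c1sc2cc(NS(=O)(=O)c3ccccc3)ccc2n1CCN1CCCCC1` gives 6%. Among these three numbers compound 1 stands at the top, yet the gap a number 5 percentage points lower from compound 1 to compound 2 (within the scatter) lies within the scatter, and the gap to compound 3 is within the scatter as well, so the three compounds cannot be told apart on these numbers.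

The step from compound 1 to compound 4 `CN(C)CCn1c(=O)sc2cc(S(=O)(=O)N(C)c3ccccc3)ccc21` alters the group on the sulfonyl sulfur: methyl(phenyl)amino in place of phenyl on a sulfonyl sulfur. For the measured compounds named here, no measured step touches this position. Going by the values given here, the only measured step, a number 5 percentage points lower from compound 1 to compound 2 (within the scatter), concerns the amine on the chain and is within the scatter. Compound 2 and compound 3 differ at the sulfonyl link; compound 2 gives 11% and compound 3 gives 6%, two values within the scatter of each other. Nothing measured points to a step beyond the scatter in this assay for the change to compound 4, and the expected step from compound 1 to compound 4 is a number 4 percentage points lower from compound 1 to compound 4 (within the scatter). Compound 4 is estimated at 12%, with a range from 2% to 26%.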

Compound 4, a percentage reported as inhibition, at one concentration (the size of the read-out at that concentration, not a potency): 5%
The estimate for compound 4 lay 7 percentage points above the measured number; the range from low to high includes it.
By their numbers in this assay, from the lowest: compounds 4, 3, 2 and 1 (each within the scatter of the next, the first and the last beyond it).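

Putting methyl(phenyl)amino in place of phenyl on the sulfonyl sulfur gives a number 11 percentage points lower from compound 1 to compound 4 (beyond the scatter) in this assay, the first step shown that passes beyond the scatter, whereas the earlier step of a number 5 percentage points lower from compound 1 to compound 2 (within the scatter) at the amine on the chain did not. This marks the sulfonyl sulfur as a place where a single change can move the read-out, although only modestly and only downward in this one case. The aromatic ring of carbon only is present on both sides of the change, so the step goes with the added nitrogen and methyl together and cannot be divided between them, and no evidence is available to explain it.

The compounds shown leave open whether phenylamino, which has the nitrogen without the methyl, or benzyl, which has a carbon in its place, would give a number like that of compound 1 or that of compound 4. They also leave open whether methyl(phenyl)amino would have a similar effect on the sulfonyl sulfur of compound 2, which carries piperidin-1-yl on the chain instead of dimethylamino.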